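Fluoroethoxy in Place of a Nitrile on the Chain

A few compounds are considered here, and "the series" means these few. Any claim that something is new, unique, unknown or untested is made for them only; others in the source may bear on it.

The compounds share one charged core and differ only in the chain attached to its second ring nitrogen. Compound 1 `C[n+]1ccn(CCC#N)c1/C=N/O` carries a short nitrile-tipped chain, compound 2 `C[n+]1ccn(CCCC#N)c1/C=N/O` a chain one carbon longer, compound 3 `COC(=O)CCCCCn1cc[n+](C)c1/C=N/O` a longer chain ending in a methyl ester, and compound 4 `C[n+]1ccn(CCOCCF)c1/C=N/O` a chain bearing a fluorinated ether.

In a physicochemical assay for lipophilicity (a lower number here means a more polar compound, a higher number a more lipophilic compound), compound 1 gives -3.3. For compound 2 the assay reports only a limit, < -3, and (the limit of < -3 in this assay, at which 1 of the 3 values shown sits). The step that the limit leaves unreadable from compound 1 to compound 2 therefore has no readable size. Among the measured compounds shown here, compound 3 gives -2.21, and the step of a number at least 0.79 log units higher from compound 2 to compound 3 (beyond the scatter) is the only measured change with a readable size.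

The change to compound 4 is 2-fluoroethoxy in place of cyanomethyl on a saturated chain carbon, two bonds along the chain from an aromatic nitrogen. Neither measured step copies it exactly: the first is unreadable, and the second removes the nitrile but brings in an ester on a longer chain. Since that second step rose clearly beyond the scatter, a rise is expected here as well, though a smaller one. The step from compound 2 to compound 4 is expected to be a number at least 0.30 log units higher from compound 2 to compound 4 (that floor lies within the scatter). Compound 4 is therefore estimated at -2.7, within -3.3 to -2.1.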

Compound 4, distribution coefficient: -2.62
Estimate against measurement, compound 4: 0.08 log units below; the range from low to high includes it.
By their numbers in this assay, from the lowest: compound 1; then compound 4; then compound 3.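

In this assay, 2-fluoroethoxy in place of cyanomethyl gives a number at least 0.38 log units higher from compound 2 to compound 4 (beyond the scatter) and so shows that a clear rise at this place on the chain can occur without an ester; the rise seen earlier arrived together with an ester and a longer chain, which made it hard to tell what the change itself contributed. Compound 1 gives the same comparison a firm size, with a number 0.68 log units higher from compound 1 to compound 4 (beyond the scatter) as 2-fluoroethoxy replaces cyano on a saturated chain carbon, two bonds along the chain from an aromatic nitrogen. Compound 2 has only a limit, < -3 in this measurement, so its step from compound 1 cannot be read and its step to compound 4 gives only a floor: the limit of < -3 in this assay, at which 1 of the 4 values shown sits.

The fluorinated ether enters as one piece, so the compounds shown do not separate the ether oxygen from the fluorine, and a plain ethoxy group at the same place would be the direct comparison. From the compounds shown here alone, how an amine or a carboxylic acid at this place would read in this assay also remains open.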